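A few compounds are considered here, and "the series" means these few. Any claim that something is new, unique, unknown or untested is made for them only; others in the source may bear on it.

In a functional assay on HL-60 cells (Homo sapiens), with a stated time of 48 h (a higher number here means that more compound is needed for the effect, a lower number that less compound is needed), compound 1 `CC1(C)CCC(C)(C)c2cc(/C=C/c3cccc(N)c3)ccc21` gives 40000 nM and compound 2 `COc1ccc(/C=C\c2ccc3c(c2)C(C)(C)CCC3(C)C)cc1N` gives 50000 nM. These two values lie within the scatter of each other, so the numbers do not separate compound 2 from compound 1. Compound 3 `COc1ccc(/C=C/c2ccc3c(c2)C(C)(C)CCC3(C)C)cc1N` has not yet been measured. Its relation to compound 2 is simple: the two compounds have the same atoms and bonds and differ only in configuration as drawn: 1 of 1 stereo elements differ; a double bond is drawn Z in compound 2 and E in compound 3. The only difference is that a double bond is drawn Z in compound 2 and E in compound 3. Within the data shown here, no measured pair shows what this change does in this assay, so the expectation rests on the two close values alone. No step beyond the scatter is expected, in either direction. The expected step is a 1.3-fold lower number from compound 2 to compound 3 (0.10 log units; within the scatter), and it stays within the scatter. Compound 3 is estimated at 40000 nM, with an expected range from 12000 nM to 100000 nM.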

Compound 3, concentration for half-maximal activity: 85000 nM
Compound 3: the middle estimate sits 2.1-fold (0.33 log units) below what was measured, within the range that was stated.
By their numbers in this assay, from the lowest: compounds 1, 2 and 3 (each within the scatter of the next, the first and the last beyond it).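

In this assay the configuration of the double bond now has a measured pair, and a 1.7-fold higher number from compound 2 to compound 3 (0.23 log units; within the scatter) leaves the two compounds unseparated, a reading that rests on a single pair with one difference: the fact that compounds 2 and 3 differ only in the configuration as drawn. Among these compounds, with the double bond drawn E in both compounds, methoxy in place of hydrogen on an aromatic carbon gives a 2.1-fold higher number from compound 1 to compound 3 (0.33 log units; beyond the scatter) and this modest step is the only one among the single changes here that lies beyond the scatter. So the methoxy group, not the configuration, is the one change that separates compounds in this small set.

The compounds shown leave open whether an ethoxy group or a fluorine in the place of the methoxy would give a similar step. They also leave open what an amide in place of the amine would do to the number.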